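The source may hold more compounds than are shown below. What is called first, only, known or untested is meant among the compounds shown, and "the series" means these compounds.

Compound 1 `CC(C(=O)NCc1ccc(C(F)(F)F)cc1N1CCCCCC1)c1ccc(NS(C)(=O)=O)c(F)c1` is tested in an assay on CHO cells for antagonist activity at transient receptor potential cation channel subfamily V member 1 (Homo sapiens), read by FLIPR (on this read-out higher numbers stand for weaker inhibition and lower numbers for stronger inhibition), where compound 1 gives 1.6 nM. Two further compounds carry a different group at the same place on the shared core. Compound 2 `Cc1ccc(N2CCN(c3cc(C(F)(F)F)ccc3CNC(=O)C(C)c3ccc(NS(C)(=O)=O)c(F)c3)CC2)cc1` gives 0.7 nM, and compound 3 `COc1ccc(N2CCN(c3cc(C(F)(F)F)ccc3CNC(=O)C(C)c3ccc(NS(C)(=O)=O)c(F)c3)CC2)cc1` gives 1.6 nM. Compound 1 is level with compound 3 at the digits shown, the two together giving the highest numbers of the three, while compound 2 gives a lower number than compound 1, beyond the scatter. Among the compounds with values here, the only measured step, a 2.3-fold higher number from compound 2 to compound 3 (0.36 log units; beyond the scatter), is modest and touches a remote part of the molecule.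

Compound 4 `CC(C)CCOc1cc(C(F)(F)F)ccc1CNC(=O)C(C)c1ccc(NS(C)(=O)=O)c(F)c1` differs from compound 1 as follows: isopentyloxy in place of azepan-1-yl on an aromatic carbon. Within the data shown here, no measured step covers this exchange, so the expectation rests on the three compounds showing that this position accepts quite different groups with only small movement in the numbers. Compound 4 is therefore expected to stay close to compound 1, with a step of a 1.9-fold higher number from compound 1 to compound 4 (0.27 log units; within the scatter), giving an estimated 3 nM, most likely between 1 nM and 10 nM.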

Compound 4, inhibition constant: 0.5 nM
Compound 4: the middle estimate sits 6.0-fold (0.78 log units) above what was measured, outside the stated range (below it).
By their numbers in this assay, from the lowest: compounds 4 and 2 (each within the scatter of the next); then compounds 1 and 3 (each within the scatter of the next).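

Exchanging the azepan-1-yl ring for the open isopentyloxy chain gives a 3.2-fold lower number from compound 1 to compound 4 (0.51 log units; beyond the scatter) in this assay, so a low number at this position requires neither a ring nor a nitrogen on the aromatic carbon. Compound 4 also lies within the scatter of compound 2, which carries a quite different, ring-bearing group at the same place, so these two groups cannot be told apart on this read-out. Nothing measured here accounts for the lower number of compound 4.

The compounds shown leave open whether the oxygen or the branching of the chain matters, as neither a straight pentyloxy chain nor a shorter ethoxy group is among them. Also open, on these data alone, is how the number would respond to an amine or a carboxylic acid at the end of the chain.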